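This account rests on a few compounds, and the source may have more. Where it says the series, first, only, none or still open, it means among the compounds named here.

Measured so far in an ADME assay on TZM cells (Homo sapiens) for cytotoxicity, read by XTT assay, with a stated time of 4 days; on this read-out higher numbers stand for lower toxicity in this test and lower numbers for higher toxicity in this test:
- compound 1 `Cc1cc(/C=C/C#N)cc(C)c1Oc1cc(Nc2ccc(C#N)cc2)c([N+](=O)[O-])cc1[N+](=O)[O-]`: > 43900 nM (a limit)
- compound 2 `Cc1cc(/C=C/C#N)cc(C)c1Oc1ccc(N)c(Nc2ccc(C#N)cc2)c1`: 25000 nM
- compound 3 `Cc1cc(/C=C/C#N)cc(C)c1Oc1cc(Nc2ccc(C#N)cc2)c(N)cc1[N+](=O)[O-]`: > 47000 nM (a limit)

The entry for compound 3, > 47000 nM, is a limit and not a number. The entry for compound 1, > 43900 nM, is also a limit. Compound 2 alone has a number in this assay, at 25000 nM.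

The next compound is compound 4 `Cc1cc(/C=C/C#N)cc(C)c1Oc1cc(Nc2ccc(C#N)cc2)c(N)cc1N`, reached from compound 3 by one change: amino in place of nitro on an aromatic carbon. This puts amino in place of nitro on an aromatic carbon, ortho to a large group and para to a (4-cyanophenyl)amino group.

Among the measured compounds shown here, two measured steps bear on this change. The same kind of exchange, at the other nitro, appears in a step that the two limits leave unreadable from compound 1 to compound 3, so it offers no size to carry over. For the measured compounds named here, the same place is changed in an at least 1.8-fold higher number from compound 2 to compound 3 (0.27 log units; that floor lies within the scatter), and that is the only usable guide. Compound 4 carries no nitro, and neither does compound 2, at 25000 nM. A small move towards a lower number is therefore expected, with nothing expected beyond the scatter. The estimate is an at least 1.4-fold lower number from compound 3 to compound 4 (0.16 log units; that floor lies within the scatter).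

For compound 4 the estimated value is 32000 nM, with an expected range from 12000 nM to 60000 nM.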

Compound 4, half-maximal cytotoxic concentration: 14400 nM
Compound 4: middle estimate off by 2.2-fold (0.35 log units), on the high side, within the range that was stated.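

In this assay, among the compounds shown here, the exchange of nitro for amino on this aromatic carbon, ortho to a large group and para to a (4-cyanophenyl)amino group, gives an at least 3.2-fold lower number from compound 3 to compound 4 (0.51 log units; beyond the scatter), a step with a readable floor, whereas the steps between the earlier compounds that involve a limit could not be read for size. The step is only a floor because the entry for compound 3 is a limit: the limit of > 47000 nM in this assay, at which 1 of the 4 values shown sits. Against compound 2, which carries hydrogen at this carbon, the amino group gives a 1.7-fold lower number from compound 2 to compound 4 (0.24 log units; within the scatter), so amino and hydrogen at this place cannot be told apart in this assay, and the shift appears only against nitro.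

On these data alone, how far the nitro compounds lie past their limits remains open, so neither the full size of this step nor any difference between compound 1 and compound 3 can be stated. Also open, as far as these compounds go, is whether other groups on this carbon, such as a methoxy group or a carboxylic acid, would fall with amino and hydrogen or with nitro.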